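This account rests on a few compounds, and the source may have more. Where it says the series, first, only, none or still open, it means among the compounds named here.

Series notes. Compound 1 `Cc1ncnc2c1c(I)cn2[C@@H]1O[C@H](CO)[C@@H](O)[C@H]1O` is the reference point. In a functional assay on HCT-116 cells (Homo sapiens), read by MTT assay, with a stated time of 72 h (on this read-out lower numbers stand for stronger inhibition and higher numbers for weaker inhibition), compound 1 gives 4720 nM, the only numerical read-out in hand for this series. Compound 2 `Cc1nc(N)c2c(-c3ccccc3)cn([C@@H]3O[C@H](CO)[C@@H](O)[C@H]3O)c2n1` carries a phenyl group and an amino group on its core instead. In this assay compound 2 reaches only > 100000 nM, which is a limit of the assay and not a number. So the limit of > 100000 nM in this assay, at which 1 of the 2 values shown sits, holds for one of the two values, and compound 1 stands alone as the measured compound.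

Compound 3 `Cc1ncnc2c1c(-c1ccoc1)cn2[C@@H]1O[C@H](CO)[C@@H](O)[C@H]1O` is not yet measured. It differs from compound 1 in one place: furan-3-yl in place of iodo on an aromatic carbon. Within the data shown here, no pair of measured compounds differs in exactly one place, so no measured step is available for comparison. Among the measured compounds shown here, compound 2 shows only that an aryl group on this core, together with an amino group, can push a compound to the limit.

The step from compound 1 to compound 3 in this assay is expected to weaken inhibition, by a 3.2-fold higher number from compound 1 to compound 3 (0.50 log units; beyond the scatter), beyond the usual scatter. Compound 3 is therefore estimated at 15000 nM, with a range from 3000 nM to 80000 nM.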

Compound 3, half-maximal inhibitory concentration: > 20000 nM
Compound 3 ended at the assay's limit (the forecaster's own chance of this, stated with the estimate: 15%); middle value at least 1.3-fold (0.12 log units) from the limit.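

The series now has its first step that changes a single place, on the aromatic carbon two ring bonds from the ring nitrogen: with furan-3-yl in place of iodo, this assay gives an at least 4.2-fold higher number from compound 1 to compound 3 (0.62 log units; beyond the scatter). Compound 2 could not show this, since it differs from compound 1 in more than one place, whereas here the weaker inhibition comes with the exchange of iodo for furan-3-yl alone, with no amino group on the core. The reading of compound 3 is a limit of the assay and not a number, and the full size of the step stays unknown: the limit of > 20000 nM in this assay, at which 1 of the 3 values shown sits.

Whether this weakening belongs to furan-3-yl in particular or extends to other groups on this carbon stays open, as the compounds shown include no methyl, nitrile or aminomethyl group there for comparison. The separate contributions of the phenyl group and the amino group in compound 2 also remain open, as no compound shown carries one of them without the other.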